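The compounds below may be only part of what the source reports. "The series", "measured", "known", "first", "only" and "open" are said of these compounds alone.

Measured so far in a functional assay on KB-VIN cells (Homo sapiens) for cytotoxicity, read by sulforhodamine B assay; a higher number here means that more compound is needed for the effect, a lower number that less compound is needed:
Compound 1, `CC1=C(O)c2c(oc(-c3ccccc3C)cc2=O)C(C)(C)C1=O`, gives 1.75 ug/mL.
Compound 2, `CCc1ccc(-c2cc(=O)c3c(o2)C(C)(C)C(=O)C(C)=C3O)cc1`, gives 1.54 ug/mL.
Compound 3, `CCC1=C(O)c2c(oc(-c3ccc(CC)cc3)cc2=O)C(CC)(CC)C1=O`, gives 0.025 ug/mL.

Compound 1 and compound 2 share a core and differ in one place, (2-methylphenyl in place of 4-ethylphenyl on an aromatic carbon). That change gave a 1.1-fold higher number from compound 2 to compound 1 (0.06 log units; within the scatter). Compound 3 has the lowest number of the three; the difference between its core and the core of compound 2 is not broken down here. Compound 4, `CCC1=C(O)c2c(oc(-c3ccccc3C)cc2=O)C(CC)(CC)C1=O`, keeps the core of compound 3 and carries the same change, (2-methylphenyl in place of 4-ethylphenyl on an aromatic carbon), at the same place. For compound 4 a similarly small step is expected, a 1.2-fold higher number from compound 3 to compound 4 (0.08 log units; within the scatter), because the same change gave a 1.1-fold higher number from compound 2 to compound 1 (0.06 log units; within the scatter) on the other core. Compound 4 is therefore estimated at 0.03 ug/mL in this assay, with a likely range from 0.012 ug/mL to 0.08 ug/mL.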

Compound 4, concentration for half-maximal effect: 0.1 ug/mL
The estimate for compound 4 lay 3.3-fold (0.52 log units) below the measured number, and the stated range ends below it.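

On the core of compound 3, putting 2-methylphenyl in place of 4-ethylphenyl gave a 4.0-fold higher number from compound 3 to compound 4 (0.60 log units; beyond the scatter) in this assay on this cytotoxicity read-out. The change therefore did not carry over at the same size from one core to the other: the same change on two cores in this assay, a 1.1-fold higher number (0.06 log units; within the scatter) from compound 2 to compound 1 and a 4.0-fold higher number (0.60 log units; beyond the scatter) from compound 3 to compound 4, 3.5-fold (0.55 log units) apart, beyond the scatter of two such steps. This shows that the size of the step depends on the core in these two pairs, but it does not show which part of the core is responsible, and two cores give no rule for a third.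

On these data alone, whether a further core would follow either step remains open. Also open, as far as these compounds go, is how a phenyl ring carrying an amine or a carboxylic acid, or one with a longer chain, would behave at this place on both cores.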